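A few compounds are considered here, and "the series" means these few. Any claim that something is new, unique, unknown or untested is made for them only; others in the source may bear on it.

Working notes on the series. Compound 1 `CCC(C)Sc1nc(C(C)c2c(F)cccc2Cl)cc(=O)[nH]1` and compound 2 `CCCCSc1nc(C(C)c2c(F)cccc2Cl)cc(=O)[nH]1` share one core; compound 3 `CCC(C)Sc1nc(C(CC)c2c(F)cccc2Cl)c(C)c(=O)[nH]1` and compound 4 `CCCCSc1nc(C(CC)c2c(F)cccc2Cl)c(C)c(=O)[nH]1` share another, and the difference between the two cores is not broken down here. In an ADME assay on MT4 cells (Homo sapiens) for activation, read by MTT assay (a higher number here means that more compound is tolerated, a lower number that less compound is tolerated), compound 1 gives only a limit, > 73000 nM. Compound 2 also gives only a limit in this assay, > 73000 nM. The change butyl in place of sec-butyl on a sulfur thus gives a step that the two limits leave unreadable from compound 1 to compound 2, both ends resting at the limit of > 73000 nM in this assay, at which 2 of the 3 values shown sit, so its size stays unreadable. Compound 3 gives only a limit in this assay, > 3000 nM, which is the limit of > 3000 nM in this assay, at which 1 of the 3 values shown sits.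

For the measured compounds named here, the change from compound 3 to compound 4 is butyl in place of sec-butyl on a sulfur, the same change as the one from compound 1 to compound 2, made at the same place. The step into compound 4 is expected at a step that the limit leaves unreadable from compound 3 to compound 4. That expectation rests on compound 1 and compound 2, whose step that the two limits leave unreadable from compound 1 to compound 2 shows no readable size, and on compound 3 sitting at the limit of > 3000 nM in this assay, at which 1 of the 3 values shown sits. Compound 4 is expected to give 20000 nM in this assay, in the range 3000 nM to 80000 nM, most likely again reported only as a limit.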

Compound 4, half-maximal cytotoxic concentration: > 3000 nM
Compound 4: no number, only a limit (the forecaster's own chance of this, stated with the estimate: 85%); the middle value lies beyond the limit too.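

Compound 3 and compound 4 both give only limits in this assay, so no new step can be read between them, and the earlier step from compound 1 to compound 2 stays equally unreadable. The compounds shown leave open whether butyl in place of sec-butyl on a sulfur changes the tolerated concentration at all, on either core.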